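The source may report more compounds than this note shows. Statements on the series, on what has been measured and on what is new or still open speak of the compounds shown alone.

Measured compounds in a physicochemical assay for pharmacokinetics, read by LC-MS, in phosphate buffer, tested at 1 uM; a lower number here means that the compound disappears faster, a higher number that the compound lasts longer:
Compound 1 `C#CCNC(=O)c1cccc2c1cc(C)n2-c1nc2c(c(NCc3ccccc3)n1)COCC2` gives > 24 h, which is a limit of the assay.
Compound 2 `CC#CCNC(=O)c1cccc2c1cc(C)n2-c1nc2c(c(NCc3ccccc3)n1)COCC2` gives > 24 h, also a limit.
Compound 3 `C#CC(=O)Nc1cccc2c1cc(C)n2-c1nc2c(c(NCc3ccccc3)n1)CCCC2` gives 0.21 h.

Compound 1 and compound 2 differ by methyl in place of hydrogen on a triple-bonded carbon. The step that the two limits leave unreadable from compound 1 to compound 2 cannot be read, because both values sit at the limit of > 24 h in this assay, at which 2 of the 3 values shown sit. Compound 3 carries another core; the difference between the two cores is not broken down here. Compound 4 `CC#CC(=O)Nc1cccc2c1cc(C)n2-c1nc2c(c(NCc3ccccc3)n1)CCCC2` is not yet measured and repeats the same change on compound 3: methyl in place of hydrogen on a triple-bonded carbon. Since compound 3 gives a number rather than a limit, the step to compound 4 should be readable; the earlier pair gives no size to lean on, so the expected step of a 7.1-fold higher number from compound 3 to compound 4 (0.85 log units; beyond the scatter) is uncertain. Compound 4 is expected to give 1.5 h in this assay, between 0.3 h and 8 h.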

Compound 4, half-life: 16.4 h
For compound 4 the middle estimate is 11-fold (1.04 log units) below the measured one, outside the stated range (above it).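

In this assay, methyl in place of hydrogen on a triple-bonded carbon gives a 78-fold higher number from compound 3 to compound 4 (1.89 log units; beyond the scatter), a large step on the core of compound 3. On the core of compound 1 the same change cannot be read, as compound 1 and compound 2 both give only a limit: the limit of > 24 h in this assay, at which 2 of the 4 values shown sit.
The change is therefore shown to matter on one core only, and neither the size nor the direction of the step is shown to carry over to the other core.

The compounds shown leave open whether a longer chain or an amine such as dimethylamino in place of the methyl would give a similar result. They also leave open how much of the difference comes from the core itself.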